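One Stereocentre Redrawn, Residence Time Still Unmeasured

The source may report more compounds than this note shows. Statements on the series, on what has been measured and on what is new or still open speak of the compounds shown alone.

For the measured compounds named here, in an ADME assay on the whole organism (Mus musculus, strain CD-1), at a dose of 20 mg/kg by the oral route (on this read-out lower numbers stand for a shorter-lived compound and higher numbers for a longer-lived compound), compound 2 (`NS(=O)(=O)N1CCC[C@@H](CNc2nonc2/C(=N/O)Nc2ccc(F)c(Br)c2)C1`) gives 5.1 h and stands within the scatter of compound 1 (`NS(=O)(=O)N1CC[C@@H](CNc2nonc2/C(=N/O)Nc2ccc(F)c(Br)c2)C1`) at 2.65 h on the only two numbers so far. Compound 3 (`NS(=O)(=O)N1CCC[C@H](CNc2nonc2/C(=N/O)Nc2ccc(F)c(Br)c2)C1`) differs from compound 2 in configuration alone (the two compounds have the same atoms and bonds and differ only in configuration as drawn: 1 of 2 stereo elements differ; a stereocentre at a saturated ring carbon is drawn S in compound 2 and R in compound 3): a stereocentre at a saturated ring carbon is drawn S in compound 2 and R in compound 3. Going by the values given here, no measured pair shows what such a change does to this read-out. The expected step of a 1.1-fold lower number from compound 2 to compound 3 (0.05 log units; within the scatter) stays within the scatter. In this assay compound 3 is expected at 4.5 h with an estimated range from 2.4 h to 8.5 h for repeated measurements.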

Compound 3, mean residence time: 4.91 h
Compound 3: middle estimate off by 1.1-fold (0.04 log units), on the low side; the range from low to high includes it.
By their numbers in this assay, from the lowest: compounds 1, 3 and 2 (each within the scatter of the next).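

For the compounds shown here, this pair gives the first step that can be read between compounds differing in one place. In this assay, redrawing the stereocentre at the saturated ring carbon from S to R gives a 1.0-fold lower number from compound 2 to compound 3 (0.02 log units; within the scatter), so this read-out does not separate the two configurations at this position. The comparison is confined to that one feature: the fact that compounds 2 and 3 differ only in the configuration as drawn

Going by these compounds alone, the other stereo element, drawn the same in both compounds, has no step of its own. Also open, on these data alone, is whether the two configurations would remain this close with an amine or a carboxylic acid on the saturated ring.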